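The source may report more compounds than this note shows. Statements on the series, on what has been measured and on what is new or still open speak of the compounds shown alone.

Compound 1 `COC(=O)/C=C/c1cccc(N(Cc2ccc(/C=C/c3c(Cl)cccc3Cl)cc2)C(=O)C(C)C)c1`: 195 nM
Compound 2 `COC(=O)/C=C/c1cccc(N(Cc2ccc(/C=C/c3scnc3C)cc2)C(=O)C2CCCCC2)c1`: 227 nM
Compound 3 `COC(=O)/C=C/c1cccc(N(Cc2ccc(/C=C/c3scnc3C)cc2)C(=O)C(C)C)c1`: 228 nM

All three were measured in an assay on isolated protein with Bile acid receptor (Homo sapiens) as the target; on this read-out higher numbers stand for an effect only at larger amounts of compound and lower numbers for an effect already at smaller amounts. Compound 2 stands second highest of these three numbers, but its neighbours sit close: the step of a 1.0-fold higher number from compound 2 to compound 3 (0.00 log units; within the scatter) is within the scatter, and the value of compound 1 differs from that of compound 2 by an amount that is likewise within the scatter. The three compounds therefore cannot be told apart on these numbers.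

Compound 4 `COC(=O)/C=C/c1cccc(N(Cc2ccc(/C=C/C(=O)N(C)C)cc2)C(=O)C2CCCCC2)c1` has not yet been measured in this assay. It differs from compound 2 in one place: dimethylcarbamoyl in place of 4-methyl-1,3-thiazol-5-yl on a double-bonded chain carbon bound to a double-bonded chain carbon

For the measured compounds named here, two measured steps bear on this. The step of a 1.2-fold higher number from compound 1 to compound 3 (0.07 log units; within the scatter) exchanged the group at the very same place and stayed within the scatter. The step of a 1.0-fold higher number from compound 2 to compound 3 (0.00 log units; within the scatter) changed a different part of the molecule and also stayed within the scatter. Neither step, however, replaced a ring with a chain at this place, so the change to compound 4 goes further than anything measured. The expectation is a modest step, a 1.5-fold higher number from compound 2 to compound 4 (0.19 log units; within the scatter), probably toward a higher number, with wide uncertainty. Compound 4 is estimated at 350 nM, in a range from 150 nM to 1000 nM.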

Compound 4, half-maximal effective concentration: > 1000 nM
Compound 4: only a limit was reported; the forecaster's own chance of this, stated with the estimate: 10%; middle value at least 2.8-fold (0.45 log units) from the limit.
By their numbers in this assay, from the lowest: compounds 1, 2 and 3 (each within the scatter of the next). At a limit, above all of these: compound 4.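

The earlier ring groups, 2,6-dichlorophenyl and 4-methyl-1,3-thiazol-5-yl, could not be told apart at this place, with a 1.2-fold higher number from compound 1 to compound 3 (0.07 log units; within the scatter), so the group here looked interchangeable; dimethylcarbamoyl, which has no ring, shows that it is not, giving an at least 4.4-fold higher number from compound 2 to compound 4 (0.64 log units; beyond the scatter). In this assay compound 4 reads > 1000 nM, which is a limit and not a number. The step therefore fixes only a lower end, not a size: the limit of > 1000 nM in this assay, at which 1 of the 4 values shown sits.

This single change removes the ring and brings in the carbonyl together, so the compounds shown cannot separate the two. As far as these compounds go, it also remains open how a carboxylic acid, a methyl ester or a pyridine ring would read at this place, and whether dimethylcarbamoyl gives a similar step with isopropyl in place of cyclohexyl on a carbonyl carbon.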